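Cyclohexyl in Place of Phenyl: From Compound 2 to Compound 3

The source may hold more compounds than are shown below. What is called first, only, known or untested is meant among the compounds shown, and "the series" means these compounds.

For the measured compounds named here, compound 2 `Cc1nc(N)sc1CCCNC(=N)NC(=O)C[C@H](C)c1ccccc1` gives the lowest of the two numbers measured so far in an in vitro functional assay on Sf9 cells for agonist activity at histamine H2 receptor (Cavia porcellus), read by GTPgammaS binding (a higher number here means that more compound is needed for the effect, a lower number that less compound is needed), namely 7.76 nM. Going by the values given here, compound 1 `Cc1nc(N)sc1CCCNC(=N)NC(=O)CC(C)c1ccccc1` gives 22.4 nM in this assay, and the only measured step, a 2.9-fold lower number from compound 1 to compound 2 (0.46 log units; beyond the scatter), rests on (the fact that one of compounds 1 and 2 is drawn with a defined configuration and the other without, at the place where they differ). Compound 3 `Cc1nc(N)sc1CCCNC(=N)NC(=O)CC(C)C1CCCCC1` differs from compound 2 by 1-cyclohexylethyl in place of 1-phenylethyl on a saturated chain carbon bound to a carbonyl carbon. Among the compounds with values here, no measured step involves a change of this kind, so the step recorded so far offers no direct guide to its size or direction. The expected step from compound 2 to compound 3 in this assay is therefore set at a 1.9-fold higher number from compound 2 to compound 3 (0.29 log units; within the scatter), a modest rise with wide uncertainty. Compound 3 is expected to give about 15 nM in this assay, within a range from 4 nM to 60 nM.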

Compound 3, half-maximal effective concentration: 7.59 nM
Compound 3: the middle estimate sits 2.0-fold (0.30 log units) above what was measured, and the stated range covers the measured number.
By their numbers in this assay, from the lowest: compounds 3 and 2 (each within the scatter of the next); then compound 1.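

In this assay, the step of a 3.0-fold lower number from compound 1 to compound 3 (0.47 log units; beyond the scatter) joins two compounds drawn without a configuration at the stereocentre, so it isolates cyclohexyl in place of phenyl and shows that, in this pair, the ring change alone gives a shift beyond the scatter. The step of a 1.0-fold lower number from compound 2 to compound 3 (0.01 log units; within the scatter) lies within the scatter, so the non-aromatic ring of carbon only, drawn without a configuration, matches the defined 1-phenylethyl compound. That second pair mixes the ring change with a difference in drawn configuration, which the earlier pair had already linked to a shift: the fact that one of compounds 1 and 2 is drawn with a defined configuration and the other without, at the place where they differ

On these data alone, how the separate configurations of the 1-cyclohexylethyl compound would compare remains open. So does what cyclopentyl or a piperidine ring would give at this place.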